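One stereocentre inverted in the 4-methylphenyl compounds

The source may report more compounds than this note shows. Statements on the series, on what has been measured and on what is new or still open speak of the compounds shown alone.

compound 1 `CC1=NN(c2ccccc2)C(=O)[C@]12C(=O)C=CC[C@H]2c1ccccc1[N+](=O)[O-]`: 12900 nM
compound 2 `CC1=NN(c2ccccc2)C(=O)[C@@]12C(=O)C=CC[C@@H]2c1ccccc1[N+](=O)[O-]`: 66400 nM
compound 3 `CC1=NN(c2ccccc2)C(=O)[C@]12C(=O)C=CC[C@H]2c1ccc(C)cc1`: 2890 nM

In a functional assay on A549 cells (Homo sapiens) for inhibition, read by MTT assay, with a stated time of 72 h (on this read-out higher numbers stand for weaker inhibition and lower numbers for stronger inhibition), compound 3 at 2890 nM holds the lowest of the three numbers, and the step of a 4.5-fold lower number from compound 1 to compound 3 (0.65 log units; beyond the scatter) came with 4-methylphenyl in place of 2-nitrophenyl. Compound 4 `CC1=NN(c2ccccc2)C(=O)[C@@]12C(=O)C=CC[C@H]2c1ccc(C)cc1` is still unmeasured and departs from compound 3 in one way only: the two compounds have the same atoms and bonds and differ only in configuration as drawn: 1 of 2 stereo elements differ; a stereocentre at a saturated ring carbon is drawn S in compound 3 and R in compound 4 and nothing more. Among the compounds with values here, one measured step bears on this change, namely a 5.1-fold higher number from compound 1 to compound 2 (0.71 log units; beyond the scatter) in the 2-nitrophenyl pair, and it can be assigned to configuration because of the fact that compounds 1 and 2 differ only in the configuration as drawn in that pair. Both stereocentres were inverted in that step, whereas only one is inverted here, and the aryl group is different, so it is only a loose guide. A rise of similar or smaller size is therefore expected in this assay for compound 4, though with wide uncertainty. The estimated step is a 2.6-fold higher number from compound 3 to compound 4 (0.41 log units; beyond the scatter) in that direction. For compound 4 the estimated value is 7500 nM with 1800 nM to 30000 nM as the expected range.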

Compound 4, half-maximal inhibitory concentration: 6090 nM
Beside the measured number, compound 4's estimate is 1.2-fold (0.09 log units) above it, and the stated range covers the measured number.
By their numbers in this assay, from the lowest: compound 3; then compound 4; then compound 1; then compound 2.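

In this assay, inverting a single stereocentre at a saturated ring carbon while the second stays as drawn gives a 2.1-fold higher number from compound 3 to compound 4 (0.32 log units; beyond the scatter), so one centre alone is enough to move the number beyond the scatter. The earlier step, a 5.1-fold higher number from compound 1 to compound 2 (0.71 log units; beyond the scatter), inverted both stereocentres at once and could not separate them, though both steps run towards a higher number and thus weaker inhibition, with 2-nitrophenyl in one pair and 4-methylphenyl in the other. The new step can be assigned to configuration alone because of what separates the pair: the fact that compounds 3 and 4 differ only in the configuration as drawn

The compounds shown leave open what the other stereocentre does when inverted alone, and whether inverting one centre has the same effect in the 2-nitrophenyl pair. They also leave open whether this holds with a chlorophenyl or a carboxylic acid in place of the 4-methylphenyl.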